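Swapping the indanyl group for an acetamidobenzyl group

A few compounds are considered here, and "the series" means these few. Any claim that something is new, unique, unknown or untested is made for them only; others in the source may bear on it.

Measured compounds:
- compound 1 `c1ccc2c(c1)CCC2NC1CCN(CCCc2c[nH]c3ccc(-n4cnnc4)cc23)CC1`: 280 nM
- compound 2 `O=S(=O)(NCC1CCN(CCCc2c[nH]c3ccc(-n4cnnc4)cc23)CC1)c1ccccc1`: 60 nM
- compound 3 `c1ccc(C2CCCCN2C2CCN(CCCc3c[nH]c4ccc(-n5cnnc5)cc34)CC2)cc1`: 410 nM

All three share one core and differ only in the group attached at the far end of the piperidine ring. In an assay on CHO cells for displacement of a labelled ligand from 5-hydroxytryptamine receptor 1B (Homo sapiens) (on this read-out higher numbers stand for weaker inhibition and lower numbers for stronger inhibition), compound 1 gives 280 nM, the second highest of the three numbers; compound 3 gives 410 nM, a gap that lies within the scatter of the assay, so the two cannot be told apart. Among the compounds with values here, the one step that stands out is a 4.7-fold lower number from compound 1 to compound 2 (0.67 log units; beyond the scatter), where a sulfonamide-bearing chain replaced the bicyclic amine substituent.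

Compound 4 `CC(=O)Nc1ccc(CNC2CCN(CCCc3c[nH]c4ccc(-n5cnnc5)cc34)CC2)cc1` is not yet measured. It differs from compound 1 by 4-acetamidobenzyl in place of 2,3-dihydro-1H-inden-1-yl on an amine nitrogen. Like the step to compound 2, this change puts a hydrogen-bond donor and acceptor where compound 1 carries none, and it also removes the saturated five-membered ring. Within the data shown here, only the step from compound 1 to compound 2 bears on it, and that step was modest. The expectation is therefore a modest move toward a lower number, with the estimate for compound 4 at 110 nM (range 35 nM to 350 nM), which means an expected step of a 2.5-fold lower number from compound 1 to compound 4 (0.41 log units; beyond the scatter).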

Compound 4, half-maximal inhibitory concentration: 45 nM
Estimate against measurement, compound 4: 2.4-fold (0.39 log units) above, and the stated range covers the measured number.
By their numbers in this assay, from the lowest: compounds 4 and 2 (each within the scatter of the next); then compounds 1 and 3 (each within the scatter of the next).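

In this assay, 4-acetamidobenzyl in place of 2,3-dihydro-1H-inden-1-yl on the amine nitrogen gives a 6.2-fold lower number from compound 1 to compound 4 (0.79 log units; beyond the scatter), a step beyond the scatter. The earlier step, a 4.7-fold lower number from compound 1 to compound 2 (0.67 log units; beyond the scatter), replaced the whole amine substituent, whereas here the amine nitrogen stays, which shows that a lower number at this end of the molecule does not depend on a phenylsulfonyl group. Nothing measured here explains the drop, and the change does several things at once: a saturated five-membered ring leaves, while a hydrogen-bond donor and acceptor enter.

The compounds shown do not separate the effect of the acetamido group from the loss of that ring, a question a plain benzyl group on the same nitrogen would address. Also open, from the compounds shown here alone, is whether a carboxylic acid or a primary amine in place of the acetamido group would keep the lower number.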